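The compounds below may be only part of what the source reports. "The series", "measured", "known", "first", "only" and "open" are said of these compounds alone.

Compound 1 `CN(C)C(=O)c1ccc(-c2cc(C3=CC(=O)C=CC3=O)no2)s1`: > 30000 nM
Compound 2 `CN(Cc1ccccc1)C(=O)c1ccc(-c2cc(C3=CC(=O)C=CC3=O)no2)s1`: > 30000 nM

In a functional assay on A549 cells (Homo sapiens) for cytotoxicity, read by XTT assay, with a stated time of 72 h (a higher number here means a weaker inhibitor, a lower number a stronger inhibitor), compound 2 gives > 30000 nM, and this is a limit of the assay, not a number. Compound 1 gives > 30000 nM, which is also a limit. The evidence so far is therefore (the limit of > 30000 nM in this assay, at which 2 of the 2 values shown sit).

The next compound is compound 3 `CCN(CC)C(=O)c1ccc(-c2cc(C3=CC(=O)C=CC3=O)no2)s1`. It keeps the shared core and changes only the amide part, with diethylamino in place of benzyl(methyl)amino on a carbonyl carbon.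

Going by the values given here, only one measured step bears on this change: a step that the two limits leave unreadable from compound 1 to compound 2. Both of its ends are limits, so it gives no size to carry over. No step beyond the usual scatter can be predicted from it, and no direction either. The likeliest outcome is that the new compound stays where the other two stand, and that this assay again reports only a limit.

The expected change is a number no higher from compound 2 to compound 3 (the limit leaves the size open), which is not a step beyond the usual scatter. The estimate for compound 3 is 30000 nM, with an expected range from 12000 nM to 60000 nM.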

Compound 3, half-maximal inhibitory concentration: 10000 nM
Compound 3: the middle estimate sits 3.0-fold (0.48 log units) above what was measured; measured number outside the range, below it.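

Compound 3 is the only one of the three that gives a real number in this assay, which shows that the group on the carbonyl carbon can move this read-out even though the shared core stays the same. Placing diethylamino there gives an at least 3.0-fold lower number from compound 2 to compound 3 (0.47 log units; beyond the scatter), and the comparison with dimethylamino gives an at least 3.0-fold lower number from compound 1 to compound 3 (0.47 log units; beyond the scatter), so both changes lead to a stronger result, and both steps lie beyond the usual scatter. The two steps start from limits of the assay and not from numbers, so they fix only the smallest possible size, and diethylamino stands apart from both the smaller dimethylamino and the larger benzyl(methyl)amino, whose compounds remain at that limit: the limit of > 30000 nM in this assay, at which 2 of the 3 values shown sit.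

The compounds shown leave open how large the two steps really are, since the true values of compound 1 and compound 2 cannot be read. They also leave open whether a longer chain on the nitrogen, such as dipropylamino, would lower the number further or return it to the limit.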